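Solubility across amide variants of one shared core

The compounds below may be only part of what the source reports. "The series", "measured", "known", "first", "only" and "open" are said of these compounds alone.

Measured compounds in a physicochemical assay for solubility, read by HPLC; on this read-out higher numbers stand for higher solubility and lower numbers for lower solubility:
- compound 1 `O=C(c1ccc(Cl)cc1)N1CCN(c2nc(=O)c3cc(C(F)(F)F)cc([N+](=O)[O-])c3s2)CC1`: 5.19 ug/mL
- compound 2 `O=C(C1CC1)N1CCN(c2nc(=O)c3cc(C(F)(F)F)cc([N+](=O)[O-])c3s2)CC1`: 52.9 ug/mL
- compound 3 `O=C(C1CCCCC1)N1CCN(c2nc(=O)c3cc(C(F)(F)F)cc([N+](=O)[O-])c3s2)CC1`: 3.24 ug/mL

Compound 3 gives the lowest of the three numbers in this assay. Its nearest neighbour is compound 1: the step of a 1.6-fold lower number from compound 1 to compound 3 (0.20 log units; within the scatter) lies within the scatter, so the two cannot be ordered. Its furthest neighbour is compound 2: the step of a 16-fold lower number from compound 2 to compound 3 (1.21 log units; beyond the scatter) is large and beyond the scatter, as is the step of a 10-fold higher number from compound 1 to compound 2 (1.01 log units; beyond the scatter) between the other two measured compounds.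

Compound 4 `CCCC(=O)N1CCN(c2nc(=O)c3cc(C(F)(F)F)cc([N+](=O)[O-])c3s2)CC1` differs from compound 3 by propyl in place of cyclohexyl on a carbonyl carbon. The step that bears most directly on this change is a 16-fold lower number from compound 2 to compound 3 (1.21 log units; beyond the scatter), where the group on the carbonyl carbon also went from a smaller to a larger one; here the cyclohexyl leaves and a three-carbon chain enters. A rise in solubility beyond the scatter is therefore expected for compound 4, though smaller than the gap between compound 2 and compound 3, since propyl is not cyclopropyl and no direct comparison is at hand. The expected step is a 5.6-fold higher number from compound 3 to compound 4 (0.74 log units; beyond the scatter). Compound 4 is estimated at 18 ug/mL, with a range from 6 ug/mL to 55 ug/mL.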

Compound 4, solubility: 2.46 ug/mL
Beside the measured number, compound 4's estimate is 7.3-fold (0.86 log units) above it; the whole stated range lies above it.
By their numbers in this assay, from the lowest: compounds 4, 3 and 1 (each within the scatter of the next, the first and the last beyond it); then compound 2.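

In this assay the step of a 1.3-fold lower number from compound 3 to compound 4 (0.12 log units; within the scatter) stays within the scatter: with cyclohexyl leaving (6 heavy atoms, one ring) and propyl entering (3 heavy atoms, no ring), the two compounds cannot be ordered. The step of a 22-fold lower number from compound 2 to compound 4 (1.33 log units; beyond the scatter) is large and the step of a 2.1-fold lower number from compound 1 to compound 4 (0.32 log units; beyond the scatter) is modest, so at this position on the carbonyl carbon compound 2 now stands clear of three other amides, and the open-chain propyl group does not share its high number. Nothing measured on these compounds accounts for this result.

Still open, on these data alone, is whether the high number of compound 2 is particular to the cyclopropyl ring. Cyclobutyl or isopropyl on the carbonyl carbon would bear on this, and a longer chain such as butyl or a chain ending in an amine would extend the comparison with propyl.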